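Shortening a Side Chain on Two Related Nucleoside Cores

This account rests on a few compounds, and the source may have more. Where it says the series, first, only, none or still open, it means among the compounds named here.

Compound 1 `CCCc1cn([C@H]2C[C@@H]3OP(=O)(O)OC[C@H]3O2)c(=O)[nH]c1=O` and compound 2 `CCCCCc1cn([C@H]2C[C@@H]3OP(=O)(O)OC[C@H]3O2)c(=O)[nH]c1=O` share one core and differ only in a side chain. In a functional assay on L1210 cells (Mus musculus) (on this read-out lower numbers stand for stronger inhibition and higher numbers for weaker inhibition), compound 1 gives > 500 ug/mL, which is a limit of the assay and not a number. Compound 2 gives > 500 ug/mL in this assay, again a limit. The change between them, (hydrogen in place of ethyl on a saturated chain carbon, three bonds along the chain from an aromatic carbon), therefore makes a step that the two limits leave unreadable from compound 2 to compound 1. Compound 3 `CCCCCc1cn([C@H]2C[C@H](O)[C@@H](CO)O2)c(=O)[nH]c1=O` carries a second core; how the two cores differ is not broken down here. In this assay, among the measured compounds shown here, compound 3 gives 477 ug/mL, the only number among the three results. The other two results sit at the limit of > 500 ug/mL in this assay, at which 2 of the 3 values shown sit. Compound 4 `CCCc1cn([C@H]2C[C@H](O)[C@@H](CO)O2)c(=O)[nH]c1=O` puts the same change, (hydrogen in place of ethyl on a saturated chain carbon, three bonds along the chain from an aromatic carbon), onto the core of compound 3. A step of a 1.3-fold higher number from compound 3 to compound 4 (0.10 log units; within the scatter) is expected, given that compound 3 sits at 477 ug/mL and that the earlier step reads a step that the two limits leave unreadable from compound 2 to compound 1. Compound 4 is expected to give 600 ug/mL, between 250 ug/mL and 1500 ug/mL, quite possibly only as a limit.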

Compound 4, concentration for 50% inhibition: > 500 ug/mL
Compound 4: a limit, no number (the forecaster's own chance of this, stated with the estimate: 70%); the middle value lies beyond the limit too.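

In this assay compound 4 gives > 500 ug/mL as its result, a limit of the assay and not a number. As far as these compounds go, the step reads an at least 1.0-fold higher number from compound 3 to compound 4 (0.02 log units; that floor lies within the scatter) and offers only a floor, so the true size of going from pentyl to propyl on this core stays unknown. The matching step on the core of compound 1 cannot be read, so nothing here shows whether the change carries from one core to the other, and the results mostly sit at a single ceiling: the limit of > 500 ug/mL in this assay, at which 3 of the 4 values shown sit.

The compounds shown leave open how a longer chain, or a chain ending in an amine or a carboxylic acid, would read on these two cores. Only measured numbers on both cores could show whether such a change carries across.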